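The source may hold more compounds than are shown below. What is called first, only, known or untested is meant among the compounds shown, and "the series" means these compounds.

Compound 1 `Cc1cc(F)cc(Nc2cc(NC(=O)Nc3c(Cl)cccc3Cl)ncn2)c1` and compound 2 `COc1cc(NC(=O)Nc2cc(Nc3ccc(F)c(Cl)c3)ncn2)cc(OC)c1` share a core. In a functional assay on NCI-H520 cells (Homo sapiens) for inhibition, read by MTT assay, with a stated time of 48 h, tested at 10 uM (on this read-out lower numbers stand for less inhibition and higher numbers for more inhibition at the one concentration tested (going by the name of the read-out)), compound 1 gives 60.5%, while compound 2 gives 25.5%, the lower of the two numbers, a gap beyond the usual scatter. Compound 3 `COc1cc(NC(=O)Nc2cc(Nc3ccc(Br)cc3OC)ncn2)cc(OC)c1` differs from compound 2 in one place: 4-bromo-2-methoxyphenyl in place of 3-chloro-4-fluorophenyl on a nitrogen on an aromatic ring. Among the measured compounds shown here, no measured pair shows this change, so nothing on the numbers speaks for a large move. The expected step is a number 4.5 percentage points higher from compound 2 to compound 3 (within the scatter), not beyond the scatter in either direction. Compound 3 is therefore estimated at 30%, in a range from 10% to 55%.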

Compound 3, a percentage reported as inhibition, at one concentration (the size of the read-out at that concentration, not a potency): 36.1%
Beside the measured number, compound 3's estimate is 6.1 percentage points below it, and the stated range covers the measured number.
By their numbers in this assay, from the lowest: compound 2; then compound 3; then compound 1.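

On a nitrogen on an aromatic ring, 4-bromo-2-methoxyphenyl in place of 3-chloro-4-fluorophenyl gives, in this assay, a number 10.6 percentage points higher from compound 2 to compound 3 (beyond the scatter). Among the compounds shown here, this is the only step here between compounds that differ in one place, and it shows that a change at this position can move the read-out, if only modestly. Nothing available explains the step.

Still open, as far as these compounds go, is whether the bromine or the methoxy group carries the step, as the two enter together. Also open, from the compounds shown here alone, is how a phenyl ring bearing an amine or a carboxylic acid would read at this position.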